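The source may report more compounds than this note shows. Statements on the series, on what has been measured and on what is new or still open speak of the compounds shown alone.

Compound 1 `CC(=O)c1ccc(Nc2ccnc(SCC(=O)c3ccc(Br)cc3)n2)cc1` gives 12% in a functional assay on MDA-MB-231 cells (Homo sapiens) for inhibition, read by sulforhodamine B assay, with a stated time of 48 h, tested at 10 uM; a lower number here means less inhibition of growth, a higher number more inhibition of growth at the concentration tested.
Compound 2 `CCOC(=O)c1ccc(Nc2ccnc(SCC(=O)c3ccc([N+](=O)[O-])cc3)n2)cc1` gives 22% in this assay.
Compound 3 `O=C(O)c1ccc(Nc2ccnc(SCC(=O)c3ccc(C(F)(F)F)cc3)n2)cc1` gives 24% in this assay.

The three measured values lie close together: the number for compound 2 sits within the usual scatter of both compound 1 and compound 3, so none of the three can be set apart from the others. Compound 4 `CCOC(=O)c1ccc(Nc2ccnc(SCC(=O)c3ccc(C#N)cc3)n2)cc1` differs from compound 2 only in one place: cyano in place of nitro on an aromatic carbon. For the measured compounds named here, no measured pair shows the effect of this exchange, so there is nothing here to suggest a shift beyond the scatter in either direction. Compound 4 is therefore expected to land near compound 2, with an estimated step from compound 2 to compound 4 of a number 2 percentage points lower from compound 2 to compound 4 (within the scatter). The estimate for compound 4 is 20%, expected to fall between 8% and 32%.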

Compound 4, percent growth inhibition at one concentration: 19%
The estimate for compound 4 lay 1 percentage points above the measured number; the range from low to high includes it.
By their numbers in this assay, from the lowest: compounds 1, 4, 2 and 3 (each within the scatter of the next, the first and the last beyond it).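

In this assay, the exchange of 4-nitrophenyl for 4-cyanophenyl, on an aromatic carbon para to a large group, gives a step of a number 3 percentage points lower from compound 2 to compound 4 (within the scatter). For the compounds shown here, this is the only single-place comparison here, and at this position it shows that cyano can stand in place of nitro with no change that can be told from the scatter. Nothing measured here gives a reason for this result. From the compounds shown here alone, whether an amine or a longer chain at this position would move the number beyond the scatter stays open, as does whether this exchange would give a similar step with a different group elsewhere on the shared core.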